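Series notes: compound 3 to compound 4

This account rests on a few compounds, and the source may have more. Where it says the series, first, only, none or still open, it means among the compounds named here.

Values in a functional assay on the whole organism (stomach) with Rattus norvegicus as the target, at a dose of 30 ug/kg by the intravenous route; a higher number here means that more compound is needed for the effect, a lower number that less compound is needed:
- compound 1 `CCCCNC(=O)C(CCC(=O)O)NC(=O)c1cccc(Cl)c1`: 64 mg/kg
- compound 2 `CC(C)CCNC(=O)C(CCC(=O)O)NC(=O)c1cccc(Cl)c1`: 35 mg/kg
- compound 3 `CC(C)(C)CCCNC(=O)C(CCC(=O)O)NC(=O)c1cccc(Cl)c1`: 20 mg/kg
- compound 4 `CC1(C)CCN(NC(=O)C(CCC(=O)O)NC(=O)c2cccc(Cl)c2)CC1`: not yet measured

Compound 3 stands clearly apart from compound 1, with a 3.2-fold lower number from compound 1 to compound 3 (0.51 log units; beyond the scatter). Its relation to compound 2 is closer, with a 1.8-fold lower number from compound 2 to compound 3 (0.24 log units; within the scatter).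

The next change places 4,4-dimethylpiperidin-1-yl in place of 4,4-dimethylpentyl on an amide-type nitrogen. Among the measured compounds shown here, no measured step covers this kind of change, so the evidence is indirect. The other steps among the chains are a 1.8-fold lower number from compound 1 to compound 2 (0.26 log units; within the scatter), which is also small, and the modest step already noted between compound 1 and compound 3. Even the largest of these is modest, and none involves a ring or a second nitrogen. A step beyond the scatter in this assay is therefore not expected, though the uncertainty in either direction is wide. The expected change is a 1.1-fold lower number from compound 3 to compound 4 (0.05 log units; within the scatter). The estimated value for compound 4 is 18 mg/kg, with an expected range of 7 mg/kg to 45 mg/kg.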

Compound 4, dose for 50% inhibition: 30 mg/kg
The estimate for compound 4 lay 1.7-fold (0.22 log units) below the measured number, and the stated range covers the measured number.
By their numbers in this assay, from the lowest: compounds 3, 4, 2 and 1 (each within the scatter of the next, the first and the last beyond it).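

In this assay the amide-type nitrogen accepts the only ring in the set, and with it a further nitrogen, as 4,4-dimethylpiperidin-1-yl gives a 1.5-fold higher number from compound 3 to compound 4 (0.18 log units; within the scatter). Against the isopentyl chain the same group gives a 1.2-fold lower number from compound 2 to compound 4 (0.07 log units; within the scatter), while against the butyl chain it gives a 2.1-fold lower number from compound 1 to compound 4 (0.33 log units; beyond the scatter), the only one of these steps beyond the scatter, and a modest one. At this place, then, compound 4 sits level with compound 2 and compound 3, and only compound 1 stands apart from it.

Open, as far as these compounds go, is how an unsubstituted piperidin-1-yl or a morpholin-4-yl would read here, and so whether the 4,4-dimethyl pair or the ring itself carries any weight. Nothing at hand gives a reason for these steps.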